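The compounds below may be only part of what the source reports. "The series", "measured", "known", "first", "only" and "open" are said of these compounds alone.

Of the compounds shown here, three built on a shared core have been tested for cytotoxicity. Compound 1 `CN1CCC(Cn2c(N)nc3ccc(C(=O)c4ccccc4)cc32)CC1`, compound 2 `CN1CCC(CCn2c(N)nc3ccc(C(=O)c4ccccc4)cc32)CC1` and compound 3 `Nc1nc2ccc(C(=O)c3ccccc3)cc2n1C[C@@H]1CCCN1` differ only in the group on a saturated chain carbon bound to an aromatic nitrogen. In an ADME assay on HL-60 cells (Homo sapiens) for cytotoxicity, read by resazurin assay, with a stated time of 72 h (a lower number here means that less compound is needed, a higher number that more compound is needed for the effect), compound 1 gives > 30000 nM, which is a limit of the assay and not a number. In this assay compound 2 gives > 30000 nM, again a limit. Compound 3 gives > 30000 nM in this assay, also a limit. So the steps a step that the two limits leave unreadable from compound 1 to compound 2, a step that the two limits leave unreadable from compound 1 to compound 3 and a step that the two limits leave unreadable from compound 2 to compound 3 cannot be sized, since all three values sit at the limit of > 30000 nM in this assay, at which 3 of the 3 values shown sit.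

Compound 4 `CN1CCC[C@@H]1Cn1c(N)nc2ccc(C(=O)c3ccccc3)cc21` has not yet been measured. It differs from compound 3 by 1-methylpyrrolidin-2-yl in place of pyrrolidin-2-yl on a saturated chain carbon bound to an aromatic nitrogen. Among the compounds with values here, none of the measured steps can be read, so no size or direction can be drawn from them; the only guide is that every measured compound reaches the limit. Compound 4 is therefore expected to give 40000 nM, within 10000 nM to 100000 nM. The step from compound 3 is estimated as a step that the limit leaves unreadable from compound 3 to compound 4, most likely again only a limit.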

Compound 4, half-maximal effective concentration: > 30000 nM
Compound 4 gave a limit, no number (the forecaster's own chance of this, stated with the estimate: 80%); the middle value does not contradict the limit.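

Compound 4 gives a limit and not a number, as do compound 1, compound 2 and compound 3, so no step among these four compounds can be read: the limit of > 30000 nM in this assay, at which 4 of the 4 values shown sit.

The compounds shown leave open what concentration each needs in this assay, and whether their groups differ in this effect at all.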